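A few compounds are considered here, and "the series" means these few. Any claim that something is new, unique, unknown or untested is made for them only; others in the source may bear on it.

Measured compounds:
Compound 1, `C#CCOc1ccc(C(C)(C)C)cc1C1(c2ccccc2)C(=O)Nc2ccccc21`. In a functional assay on CRL2813 cells (Homo sapiens) for antiproliferative activity, read by sulforhodamine B assay, with a stated time of 5 days (a higher number here means a weaker inhibitor, a lower number a stronger inhibitor), compound 1 gives > 20000 nM, which is a limit of the assay.
Compound 2, `CC(C)(C)c1ccc(OCC(=O)O)c(C2(c3ccccc3)C(=O)Nc3ccccc32)c1`. In this assay compound 2 gives > 20000 nM, also a limit of the assay.
Compound 3, `COc1ccc(C2(c3cc(C(C)(C)C)ccc3O)C(=O)Nc3ccccc32)cc1`. In this assay compound 3 gives 2750 nM.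

Compound 3 thus stands as the only one of the three with a number; the other two sit at the limit of > 20000 nM in this assay, at which 2 of the 3 values shown sit. Among the compounds with values here, the one measured step, a step that the two limits leave unreadable from compound 1 to compound 2, changes a different part of the molecule and cannot be read in size, so it does not bear on the change considered here. Compound 4, `CN(C)c1ccc(C2(c3cc(C(C)(C)C)ccc3O)C(=O)Nc3ccccc32)cc1`, differs from compound 3 by dimethylamino in place of methoxy on an aromatic carbon. Within the data shown here, with no measured step bearing on this change, no difference beyond the scatter is expected, and the step from compound 3 to compound 4 is estimated at a 1.1-fold lower number from compound 3 to compound 4 (0.04 log units; within the scatter). Compound 4 is therefore expected to give about 2500 nM, in the range 800 nM to 8000 nM.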

Compound 4, half-maximal inhibitory concentration: 11000 nM
The estimate for compound 4 lay 4.4-fold (0.64 log units) below the measured number; measured number above the stated range.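

On the aromatic carbon para to a large group, the change from 4-methoxyphenyl to 4-(dimethylamino)phenyl is not neutral: in this assay it gives a 4.0-fold higher number from compound 3 to compound 4 (0.60 log units; beyond the scatter). Within the data shown here, this is the first readable step at this position, and it shows that the position responds to the group it carries, with methoxy giving the stronger inhibitor of this pair. Nothing shown gives a cause for this step.

The compounds shown leave open how a primary amine, a carboxylic acid or a longer alkoxy chain would fare at this position. They also leave open whether any group there improves on methoxy.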